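Nitro for fluoro at the phenoxy ring: lipophilicity notes

This account rests on a few compounds, and the source may have more. Where it says the series, first, only, none or still open, it means among the compounds named here.

Compound 1 `Cc1ccc(Oc2ccc(/C=N/Nc3nc4ccccc4s3)cc2)cc1` gives 5.4 in a physicochemical assay for lipophilicity, in phosphate buffer, measured as octanol-water partition, with a stated time of 24 h; a higher number here means a more lipophilic compound, a lower number a more polar compound. Going by the values given here, compound 3 `C(=N/Nc1nc2ccccc2s1)\c1ccc(Oc2ccccc2)cc1` gives 5.2; the one step measured, a number 0.20 log units lower from compound 1 to compound 3 (within the scatter), exchanges a methyl for hydrogen on an aromatic carbon. Compound 2 `O=C(CSc1nc2ccccc2s1)N/N=C/c1ccc(Oc2ccc(F)cc2)cc1` gives 5.5, the largest of the three numbers, though all three lie within the scatter of one another. Compound 4 `O=C(CSc1nc2ccccc2s1)N/N=C/c1ccc(Oc2ccc([N+](=O)[O-])cc2)cc1` differs from compound 2 by nitro in place of fluoro on an aromatic carbon, sited para to a large group. Among the compounds with values here, no measured step involves a nitro or a fluoro, so the three values fix only the level of the series, not the size of this change. For compound 4 a modest fall, a number 0.40 log units lower from compound 2 to compound 4 (beyond the scatter), is expected in this assay. Compound 4 is therefore estimated at 5.1, between 4.6 and 5.6.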

Compound 4, partition coefficient: 5.3
The estimate for compound 4 lay 0.20 log units below the measured number; measured number inside the range.
By their numbers in this assay, from the lowest: compounds 3, 4, 1 and 2 (each within the scatter of the next).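

In this assay, the change from 4-fluorophenoxy to 4-nitrophenoxy gives a number 0.20 log units lower from compound 2 to compound 4 (within the scatter) and is the only step shown that involves either group. Here, one heavy atom gives way to three, and two hydrogen-bond acceptors enter, yet the two compounds remain within the scatter of each other. No evidence on the cause of this result is at hand. Open, going by these compounds, is how an amine, a carboxylic acid or a longer chain would read at this position, and whether the same exchange on the core of compound 1 would read alike.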